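Compound 4: Octyl in Place of 2-Fluorophenyl

The source may report more compounds than this note shows. Statements on the series, on what has been measured and on what is new or still open speak of the compounds shown alone.

Of the compounds shown here, three built on a shared core have been tested in an ADME assay on HEK293 cells (Homo sapiens) for cytotoxicity, read by sulforhodamine B assay, with a stated time of 48 h, tested at 10 uM; a higher number here means more inhibition at the concentration tested (going by the name of the read-out), a lower number less inhibition. Compound 1 `COc1nc2ccc(Br)cc2cc1C(c1ccccc1)n1cc(-c2ccccc2F)nn1` gives 3.97%, compound 2 `COc1nc2ccc(Br)cc2cc1C(c1ccccc1)n1cc(-c2ccc(Br)cc2)nn1` gives 6.28%, and compound 3 `COc1nc2ccc(Br)cc2cc1C(c1ccccc1)n1cc(CCCCCO)nn1` gives 7.96%. Compound 1 holds the lowest of the three numbers; its nearest neighbour lies a step of a number 2.3 percentage points higher from compound 1 to compound 2 (within the scatter) away, and its furthest a step of a number 4 percentage points higher from compound 1 to compound 3 (within the scatter). Compound 4 `CCCCCCCCc1cn(C(c2ccccc2)c2cc3cc(Br)ccc3nc2OC)nn1` has not yet been measured in this assay. It differs from compound 1 in one place: octyl in place of 2-fluorophenyl on an aromatic carbon. Both measured steps away from compound 1 bear on this change, since each also replaces the 2-fluorophenyl on the same aromatic carbon, and the step to compound 3, which brings in 5-hydroxypentyl, is the closer parallel to octyl. Both of those steps stayed within the scatter, so no step beyond the scatter is expected in this assay in either direction. Compound 4 is expected to give 6%, with a range from 0% to 16%. That estimate amounts to an expected step of a number 2 percentage points higher from compound 1 to compound 4 (within the scatter).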

Compound 4, a percentage reported as inhibition, at one concentration (the size of the read-out at that concentration, not a potency): 14.6%
Compound 4: middle estimate off by 8.6 percentage points, on the low side; the measured number falls inside the stated range.
By their numbers in this assay, from the lowest: compounds 1, 2, 3 and 4 (each within the scatter of the next, the first and the last beyond it).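

In this assay, going by these compounds alone, octyl gives the only step from compound 1 at this aromatic carbon that lies beyond the scatter, a number 10.6 percentage points higher from compound 1 to compound 4 (beyond the scatter), whereas the earlier replacements of 2-fluorophenyl stayed within it. The other two new steps do not set octyl apart from 5-hydroxypentyl or 4-bromophenyl: they are a number 6.6 percentage points higher from compound 3 to compound 4 (within the scatter) and a number 8.3 percentage points higher from compound 2 to compound 4 (within the scatter), so the difference is established only against 2-fluorophenyl. Nothing measured here accounts for the step from 2-fluorophenyl to octyl.

As far as these compounds go, whether a shorter chain such as butyl or a longer chain such as dodecyl would give a different number at this position remains open. So does whether an amine or a carboxylic acid at the end of the octyl chain would preserve the step.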